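A few compounds are considered here, and "the series" means these few. Any claim that something is new, unique, unknown or untested is made for them only; others in the source may bear on it.

In a physicochemical assay for lipophilicity, using the shake flask method, measured as octanol-water partition, at pH 7.4 (a higher number here means a more lipophilic compound, a lower number a more polar compound), compound 1 `CC(=O)N[C@H]1[C@H]([C@@H](O)[C@H](O)CNC(=O)c2ccc(Cl)cc2)O[C@@](OCc2ccccc2)(C(=O)O)C[C@@H]1O` stands as "not determined" (no result reported), compound 2 `CC(=O)N[C@H]1[C@H]([C@@H](O)[C@H](O)CNC(=O)c2ccc(Cl)cc2)O[C@@](OCc2ccc(Cl)cc2)(C(=O)O)C[C@@H]1O` gives 0.36 and compound 3 `CC(=O)N[C@H]1[C@H]([C@@H](O)[C@H](O)CNC(=O)c2ccc(Cl)cc2)O[C@@](OCc2ccc(F)cc2)(C(=O)O)C[C@@H]1O` gives -0.11, the lower of the two numbers. Compound 4 `CC(=O)N[C@H]1[C@H]([C@@H](O)[C@H](O)CNC(=O)c2ccc(Cl)cc2)O[C@@](OCc2c(F)c(F)c(F)c(F)c2F)(C(=O)O)C[C@@H]1O` differs from compound 3 as follows: 2,3,4,5,6-pentafluorophenyl in place of 4-fluorophenyl on a saturated chain carbon bound to an oxygen on a saturated carbon. In short, 2,3,4,5,6-pentafluorophenyl stands in place of 4-fluorophenyl on a saturated chain carbon bound to an oxygen on a saturated carbon. Among the measured compounds shown here, only one measured step bears on this, and only loosely: a number 0.47 log units lower from compound 2 to compound 3 (beyond the scatter), with fluoro in place of chloro on an aromatic carbon. It exchanges one halogen for another and adds none, so it sets a scale and does not fix a direction. A modest rise in this assay is expected, of similar size: a number 0.56 log units higher from compound 3 to compound 4 (beyond the scatter). For compound 4 the estimate is 0.45, with an expected range of 0 to 0.9.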

Compound 4, distribution coefficient: -0.11
Compound 4: the middle estimate sits 0.56 log units above what was measured, and the stated range ends above it.
By their numbers in this assay, from the lowest: compounds 3 and 4 (each within the scatter of the next); then compound 2.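

In this assay the 2,3,4,5,6-pentafluorophenyl and 4-fluorophenyl groups do not separate at this position, with no change at the digits printed from compound 3 to compound 4 (within the scatter) despite 5 fluorine against 1 on the ring. Against 4-chlorophenyl the two fluorinated rings read alike, with a number 0.47 log units lower from compound 2 to compound 3 (beyond the scatter) matched by a number 0.47 log units lower from compound 2 to compound 4 (beyond the scatter) in a gap of equal size, so compound 2 alone stands apart among the three numbers. No available data explain the flat step.

On these data alone, whether a ring carrying trifluoromethyl or an amine would shift this reading remains open. A longer chain between the oxygen and the ring is also untested here.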